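A Hydroxy Group on the Amide Chain of Compound 1

The source may hold more compounds than are shown below. What is called first, only, known or untested is meant among the compounds shown, and "the series" means these compounds.

Compound 1 `CCNC(=O)CC1CCc2cc(OC)c(OC)cc21` was tested in a functional assay on the whole organism (strain Wistar) for inhibition, with Rattus norvegicus as the target, read by paw edema, with stated times of 60 min and 6 h, at a dose of 100 mg/kg by the oral route (on this read-out lower numbers stand for less inhibition and higher numbers for more inhibition at the one dose given (going by the name of the read-out)), where compound 1 gives 20.4%. Among the two measured compounds this is the lowest number, but only by a margin that falls within the scatter: compound 2 `CCCCNC(=O)CC1CCc2cc(OC)c(OC)cc21` gives 24.1% in this assay, and the step of a number 3.7 percentage points higher from compound 1 to compound 2 (within the scatter) is one of these small movements. For the measured compounds named here, that step replaces hydrogen with ethyl on the chain attached to the amide nitrogen, so it is the only measured change at the same place as the one considered here.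

Compound 3 `COc1cc2c(cc1OC)C(CC(=O)NCCO)CC2` has not been measured. It differs from compound 1 by hydroxy in place of hydrogen on a saturated chain carbon, two bonds along the chain from an amide-type nitrogen. Going by the values given here, no measured step introduces a hydroxy group, so the only guide is that adding carbon at this place left the number essentially unchanged. On that basis the expected step is a number 1.6 percentage points higher from compound 1 to compound 3 (within the scatter), that is, none beyond the scatter. Compound 3 is therefore estimated to give 22% in this assay. Among the compounds with values here, the expected range for compound 3 runs from 8% to 38%, a wide band because the single relevant step a number 3.7 percentage points higher from compound 1 to compound 2 (within the scatter) says little about an oxygen-bearing group.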

Compound 3, a percentage reported as inhibition, in the whole organism at one dose (the size of the read-out at that dose, not a potency): 13%
Estimate against measurement, compound 3: 9 percentage points above; low and high end bracket the measured number.
By their numbers in this assay, from the lowest: compounds 3, 1 and 2 (each within the scatter of the next, the first and the last beyond it).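

In this assay, the step of a number 7.4 percentage points lower from compound 1 to compound 3 (within the scatter) means that the hydroxy group cannot be told apart from hydrogen at this place on the chain. The step of a number 11.1 percentage points lower from compound 2 to compound 3 (beyond the scatter) is a different matter: it gives the first gap at this place to lie beyond the scatter, so the choice of group here can move the read-out modestly, with hydroxy and ethyl standing apart and hydrogen within the scatter of both. Nothing available explains why hydroxy and ethyl differ.

From the compounds shown here alone, it remains open whether this gap depends on the oxygen, on its hydrogen, or simply on the loss of the ethyl carbons; a methoxy group at the same place would begin to separate these possibilities, as would a longer chain ending in hydroxy. An amine or a carboxylic acid at this place would show whether other groups also stay within the scatter of hydrogen or move the number further, in either direction, at the single dose used here.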